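A few compounds are considered here, and "the series" means these few. Any claim that something is new, unique, unknown or untested is made for them only; others in the source may bear on it.

In a functional assay on MCF7 cells (Homo sapiens) for antiproliferative activity, read by sulforhodamine B assay, with a stated time of 48 h (on this read-out higher numbers stand for weaker inhibition and lower numbers for stronger inhibition), compound 1 `CC(C)(C)c1ccc(NS(=O)(=O)c2ccc(N3CCNC3=O)cc2)cc1` gives > 1000 nM, which is a limit of the assay and not a number. A close relative, compound 2 `CC(C)(C)c1cc(NS(=O)(=O)c2ccc(N3CCNC3=O)cc2)cc(C(C)(C)C)c1`, gives > 1000 nM, and this too is a limit. Both results therefore sit at the same boundary, (the limit of > 1000 nM in this assay, at which 2 of the 2 values shown sit), so neither can be ranked against the other, and compound 1 offers only a bound as a starting point.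

The next compound to consider is compound 3 `CCCCCc1ccc(NS(=O)(=O)c2ccc(N3CCNC3=O)cc2)cc1`, which keeps the shared core and changes one group: pentyl in place of tert-butyl on an aromatic carbon, para to a large group, (pentyl in place of tert-butyl on an aromatic carbon). For the measured compounds named here, no measured pair here shows what a swap of this kind does, so the data offer no direct guide to the size of the step. In this assay, no change beyond the usual scatter is expected. That expectation rests only on compound 1 and its limit, > 1000 nM. The expected step is a step that the limit leaves unreadable from compound 1 to compound 3. Compound 3 is estimated at 2000 nM, with an expected range of 800 nM to 8000 nM.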

Compound 3, half-maximal inhibitory concentration: > 1000 nM
Compound 3 ended at the assay's limit; the forecaster's own chance of this, stated with the estimate: 65%; the middle value does not contradict the limit.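

In this assay compound 3 gives > 1000 nM and this is a limit, not a number. For the compounds shown here, compound 1 also gave only a limit, so no step from compound 1 to compound 3 can be read. The compounds shown leave open how strongly each one acts and whether pentyl and tert-butyl differ at all, as all share one boundary: the limit of > 1000 nM in this assay, at which 3 of the 3 values shown sit.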